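Cytotoxicity Outlook for a Cyclopropyl Variant

The compounds below may be only part of what the source reports. "The series", "measured", "known", "first", "only" and "open" are said of these compounds alone.

Measured compounds so far:
- Compound 1 `Cc1ccc(CCCN2CCc3nc(C)c([C@H](OC(C)(C)C)C(=O)O)c(-c4cc(F)c5c(c4C)CCCO5)c3C2)cc1F`: in an ADME assay on MT2 cells (Homo sapiens) for cytotoxicity, read by XTT assay, with a stated time of 4 days (on this read-out higher numbers stand for lower toxicity in this test and lower numbers for higher toxicity in this test), compound 1 gives > 40000 nM, which is a limit of the assay and not a number.
- Compound 2 `Cc1cccc(CCCN2CCc3nc(C)c([C@H](OC(C)(C)C)C(=O)O)c(-c4cc(F)c5c(c4C)CCCO5)c3C2)c1`: in this assay compound 2 gives > 40000 nM, again a limit rather than a number.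
- Compound 3 `CC(=O)N1CCc2nc(C)c(C(OC(C)(C)C)C(=O)O)c(-c3ccc(C)cc3)c2C1`: in this assay compound 3 gives > 40000 nM, also a limit.

Compound 2 therefore stands at the limit of this assay, alongside every other measured compound; none of them shows a readable number.

The unmeasured compound 4 `Cc1nc2c(c(-c3cc(F)c4c(c3C)CCCO4)c1[C@H](OC(C)(C)C)C(=O)O)CN(CC1CC1c1ccccc1)CC2` differs from compound 2 in one place: 2-phenylcyclopropyl in place of 2-(3-methylphenyl)ethyl on a saturated chain carbon bound to an amine nitrogen in a ring.

Among the measured compounds shown here, only one measured step resembles this change, from compound 1 to compound 2, and it reads a step that the two limits leave unreadable from compound 1 to compound 2, so its size is unknown. For the measured compounds named here, the one piece of evidence that speaks to the whole set is the limit of > 40000 nM in this assay, at which 3 of the 3 values shown sit. Nothing measured here points to a step in either direction beyond the scatter, and the chance is high that compound 4 again returns only a limit.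

For compound 4 the expected result in this assay is 50000 nM, with a range from 20000 nM to 150000 nM, which means an expected step that the limit leaves unreadable from compound 2 to compound 4.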

Compound 4, half-maximal cytotoxic concentration: > 40000 nM
Compound 4 gave a limit, no number; the forecaster's own chance of this, stated with the estimate: 85%; the middle value lies beyond the limit too.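

In this assay compound 4 gives > 40000 nM, a limit and not a number. The steps to compound 4 from compound 1 and compound 2 therefore cannot be read. Still open is the concentration at which any of these compounds turns toxic, and whether 2-phenylcyclopropyl in place of 2-(3-methylphenyl)ethyl changes it, with all results resting on one shared limit: the limit of > 40000 nM in this assay, at which 4 of the 4 values shown sit.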